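Swapping bromo for trifluoromethyl on the aromatic ring

The source may report more compounds than this note shows. Statements on the series, on what has been measured and on what is new or still open speak of the compounds shown alone.

Compound 1 `S=C(Nc1ccccc1)N1N=C(c2ccccc2)CC1c1ccc2c(c1)OCCO2`: 3180 nM
Compound 2 `S=C(Nc1ccccc1)N1N=C(c2ccc(Cl)cc2)CC1c1ccc2c(c1)OCCO2`: > 200000 nM (a limit of the assay, not a number)
Compound 3 `S=C(Nc1ccccc1)N1N=C(c2ccc(Br)cc2)CC1c1ccc2c(c1)OCCO2`: 870 nM

The three compounds were tested in a functional assay on WM 266-4 cells (Homo sapiens) for antiproliferative activity, read by MTT assay, with a stated time of 48 h; on this read-out lower numbers stand for stronger inhibition of growth and higher numbers for weaker inhibition of growth. Compound 3 gives the lowest number, 870 nM. Among the compounds with values here, the only other true number comes from compound 1, at 3180 nM. Compound 2 reached only a limit of the assay, > 200000 nM, a limit also noted as the limit of > 200000 nM in this assay, at which 1 of the 3 values shown sits.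

Compound 4 `FC(F)(F)c1ccc(C2=NN(C(=S)Nc3ccccc3)C(c3ccc4c(c3)OCCO4)C2)cc1` keeps the rest of compound 3 but has trifluoromethyl in place of bromo on an aromatic carbon, para to a large group (trifluoromethyl in place of bromo on an aromatic carbon). In other words, 4-bromophenyl becomes 4-(trifluoromethyl)phenyl.

Three measured steps involve this same spot. Adding bromo gave a modest change, a 3.7-fold lower number from compound 1 to compound 3 (0.56 log units; beyond the scatter). Adding chloro gave a large one in the opposite direction, an at least 62-fold higher number from compound 1 to compound 2 (1.79 log units; beyond the scatter). Exchanging chloro for bromo was also large, an at least 220-fold lower number from compound 2 to compound 3 (2.36 log units; beyond the scatter). Small swaps here can therefore matter a great deal, and none of the measured compounds carries trifluoromethyl.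

Compound 3 already has the lowest number, so a modest rise seems more likely than a further fall. The expected step in this assay is a 2.3-fold higher number from compound 3 to compound 4 (0.36 log units; beyond the scatter), with wide uncertainty. The estimate for compound 4 is 2000 nM, with an expected range of 400 nM to 15000 nM.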

Compound 4, concentration for 50% growth inhibition: 52400 nM
Compound 4: the middle estimate sits 26-fold (1.42 log units) below what was measured; the whole stated range lies below it.
By their numbers in this assay, from the lowest: compound 3; then compound 1; then compound 4. At a limit, above all of these: compound 2.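

In this assay, the gain seen with bromo does not carry over to trifluoromethyl, a group of four heavy atoms in place of one at the same spot (a 60-fold higher number from compound 3 to compound 4 (1.78 log units; beyond the scatter)). Set against the unsubstituted phenyl of compound 1, trifluoromethyl also moves the number the wrong way (a 16-fold higher number from compound 1 to compound 4 (1.22 log units; beyond the scatter)), so among the groups tested here bromo is the only one that lowers it, and both chloro and trifluoromethyl go against it. The step from chloro to trifluoromethyl can be given only as a bound (an at least 3.8-fold lower number from compound 2 to compound 4 (0.58 log units; beyond the scatter)), since compound 2 holds a limit of the assay and not a number: (the limit of > 200000 nM in this assay, at which 1 of the 4 values shown sits).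

The compounds shown do not explain why bromo alone lowers the number while its neighbours in this small set raise it, and four groups at one spot are too few to give a rule. On these data alone, a methyl, a methoxy, an iodo or a nitrile at this same spot could show whether bromo is a lone exception, and it remains open whether the same order holds in other cell lines.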